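Amide-chain substitution on the shared core: compound 4

A few compounds are considered here, and "the series" means these few. Any claim that something is new, unique, unknown or untested is made for them only; others in the source may bear on it.

Series notes. Compound 1 `Cn1c(-c2ccc(NC(=O)CCl)cc2)nc(-c2ccccc2)c1-c1ccccc1` carries a chloro on a saturated chain carbon bound to a carbonyl carbon. In a functional assay on MCF7 cells (Homo sapiens) for cytotoxicity, read by MTT assay, with a stated time of 24 h, tested at 1.6 ug/mL (a higher number here means a stronger effect of the compound at the concentration tested, a lower number a weaker effect), compound 1 gives 4.3%. Among the three measured compounds it stands second highest: compound 2 `Cn1nnnc1SCC(=O)Nc1ccc(-c2nc(-c3ccccc3)c(-c3ccccc3)n2C)cc1` gives 34.3%, and compound 3 `CN(C)/C=C/N1CCN(CC(=O)Nc2ccc(-c3nc(-c4ccccc4)c(-c4ccccc4)n3C)cc2)CC1` gives 1.9%. The step of a number 30 percentage points higher from compound 1 to compound 2 (beyond the scatter) is beyond the scatter, whereas a number 2.4 percentage points lower from compound 1 to compound 3 (within the scatter) is within it, so compound 1 and compound 3 cannot be ordered against each other. Between the other two, a number 32.4 percentage points lower from compound 2 to compound 3 (beyond the scatter).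

Compound 4 `Cn1c(-c2ccc(NC(=O)CN3CCN(c4ccccc4)CC3)cc2)nc(-c2ccccc2)c1-c1ccccc1` is not yet measured. It differs from compound 1 in one place: 4-phenylpiperazin-1-yl in place of chloro on a saturated chain carbon bound to a carbonyl carbon. Of the measured steps, the exchange of chloro for a piperazin-1-yl bearing group is seen once, in a number 2.4 percentage points lower from compound 1 to compound 3 (within the scatter), with no shift beyond the scatter; the only sizeable rise, a number 30 percentage points higher from compound 1 to compound 2 (beyond the scatter), came with (1-methyl-1H-tetrazol-5-yl)sulfanyl, not with a piperazine. Nothing in the series shows that 4-phenylpiperazin-1-yl behaves otherwise than 4-(2-(dimethylamino)ethenyl)piperazin-1-yl did in compound 3, so no step beyond the scatter is expected in this assay. The estimate for compound 4 is 4%, with a range from 0% to 18%. This corresponds to an expected step of a number 0.3 percentage points lower from compound 1 to compound 4 (within the scatter).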

Compound 4, a percentage reported as activity, at one concentration (the size of the read-out at that concentration, not a potency): 21.3%
Estimate against measurement, compound 4: 17.3 percentage points below; the whole stated range lies below it.
By their numbers in this assay, from the lowest: compounds 3 and 1 (each within the scatter of the next); then compound 4; then compound 2.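

Working notes on the chain position. In this assay, the piperazine ring does not by itself fix the outcome at this position, since phenyl in place of 2-(dimethylamino)ethenyl on the ring amine nitrogen gives a number 19.4 percentage points higher from compound 3 to compound 4 (beyond the scatter) and so the group carried on that nitrogen counts. The (1-methyl-1H-tetrazol-5-yl)sulfanyl group is also no longer the only replacement for chloro on the saturated chain carbon bound to a carbonyl carbon that shifts the read-out, as 4-phenylpiperazin-1-yl gives a number 17 percentage points higher from compound 1 to compound 4 (beyond the scatter) while still falling short of the tetrazole compound, with a number 13 percentage points lower from compound 2 to compound 4 (beyond the scatter) in the same assay. No measurement at hand accounts for the difference between these groups.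

The compounds shown leave open whether the aromatic ring must sit directly on the piperazine nitrogen, which a benzyl or a 2-pyridyl group there would test. They also leave open whether the piperazine is needed at all, a question that morpholine or an open-chain diethylamino group on the chain carbon would address, as well as whether the shift survives at other concentrations.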